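The source may report more compounds than this note shows. Statements on the series, on what has been measured and on what is new or still open speak of the compounds shown alone.

Measured compounds in a functional assay on HEK293 cells for agonist activity at D(4) dopamine receptor (Homo sapiens), read by FLIPR; on this read-out higher numbers stand for larger maximal responses and lower numbers for smaller maximal responses:
compound 1 `Cc1cc(NC(=O)CN2CCC(c3cccc[n+]3[O-])CC2)ccc1F`: 75%
compound 2 `Cc1cccc(C(=O)NCN2CCC(c3ccccn3)CC2)c1`: 67%

Compound 1 holds the higher of the two numbers, but compound 2 sits within the usual scatter of it, so no order between the two can be drawn from these values. For the measured compounds named here, no pair of measured compounds differs in only one place, so no single structural step has been characterised so far.

The next compound, compound 3 `O=C(CN1CCC(c2cccc[n+]2[O-])CC1)Nc1ccc(F)cc1`, differs from compound 1 in one place: hydrogen in place of methyl on an aromatic carbon. The change removes a methyl group and leaves the rest of compound 1 as it is. No measured pair shows this change, so its effect is unknown from the data at hand; with compound 1 at 75% and no shown step of this kind, only a small step in either direction, or none beyond the scatter, is expected in this assay.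

The estimate for compound 3 is 70% (range 50% to 90%). This amounts to an expected step of a number 5 percentage points lower from compound 1 to compound 3 (within the scatter), which is expected to fall within the scatter.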

Compound 3, largest response reached (reported as efficacy), in percent of the reference or control that the assay uses: 71%
Compound 3: middle estimate off by 1 percentage points, on the low side; the range from low to high includes it.
By their numbers in this assay, from the lowest: compounds 2, 3 and 1 (each within the scatter of the next).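

In this assay, replacing methyl with hydrogen in the 4-fluoro-3-methylphenyl to 4-fluorophenyl change gives a number 4 percentage points lower from compound 1 to compound 3 (within the scatter). For the compounds shown here, this is the first single-place step, and it shows that the methyl group on this aromatic carbon, ortho to a fluoro group and meta to a large group, is not needed to retain a maximal response of this size, at least on the 4-fluorophenyl background of compound 3. No independent measurement bears on this result.

The compounds shown leave open whether a chlorine atom, a methoxy group or an ethyl group on the same aromatic carbon would move the maximal response beyond the scatter, since the methyl-to-hydrogen step samples only two substituents at this position. They also leave open what the fluoro group contributes, since it is present in both compound 1 and compound 3, and a step to hydrogen or to a chlorine atom at that carbon would be needed to show whether it matters for the response.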